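Swapping the Aryl Group on a Saturated Ring Carbon

This account rests on a few compounds, and the source may have more. Where it says the series, first, only, none or still open, it means among the compounds named here.

Compound 2 `CCn1cc(C(=O)N2N=C(c3cc4ccccc4o3)CC2c2ccc(OC)cc2O)c(=O)c2ccc(C)nc21` sits at a limit in an ADME assay on Vero cells (Chlorocebus sabaeus) for cytotoxicity, read by MTT assay, with a stated time of 72 h; a lower number here means a stronger inhibitor, a higher number a weaker inhibitor: compound 2 gives > 154000 nM, which is a limit of the assay and not a number. Compound 1 `CCn1cc(C(=O)N2N=C(c3cc4ccccc4o3)CC2c2ccc(N(C)C)cc2)c(=O)c2ccc(C)nc21` likewise gives only a limit in this assay, > 206000 nM. Among the measured compounds shown here, the one measured step, a step that the two limits leave unreadable from compound 1 to compound 2, stays unreadable because its two ends are the limit of > 154000 nM in this assay, at which 1 of the 2 values shown sits, and (the limit of > 206000 nM in this assay, at which 1 of the 2 values shown sits). Compound 3 `CCn1cc(C(=O)N2N=C(c3cc4ccccc4o3)CC2c2ccccc2Cl)c(=O)c2ccc(C)nc21` differs from compound 2 by 2-chlorophenyl in place of 2-hydroxy-4-methoxyphenyl on a saturated ring carbon. Nothing measured points to a change beyond the scatter, so compound 3 is expected to give 180000 nM, in a range from 60000 nM to 400000 nM. The expected step is therefore a step that the limit leaves unreadable from compound 2 to compound 3.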

Compound 3, half-maximal inhibitory concentration: > 178000 nM
Compound 3: a limit, no number; the forecaster's own chance of this, stated with the estimate: 65%; the middle value is on the limit's open side.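

Among the compounds shown here, compound 3 gives only a limit, as do compound 1 and compound 2, so no step from compound 1 or compound 2 to compound 3 can be read. In this assay the compounds shown leave open what actual number each would give.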